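From Chloro to Methyl: What to Expect of Compound 4

The source may hold more compounds than are shown below. What is called first, only, known or untested is meant among the compounds shown, and "the series" means these compounds.

Compound 1 `COc1ccc(NC(=O)Nc2cccc(CNc3nccnc3Cl)c2)cc1`: 12000 nM
Compound 2 `CN(C)c1ccc(NC(=O)Nc2cccc(CNc3nccnc3Cl)c2)cc1`: > 40000 nM (a limit of the assay, not a number)
Compound 3 `O=C(Nc1cccc(Cl)c1)Nc1cccc(CNc2nccnc2Cl)c1`: 9140 nM

In a functional assay on HepG2 cells (Homo sapiens) for antiproliferative activity, read by MTT assay, with a stated time of 48 h (on this read-out higher numbers stand for weaker inhibition and lower numbers for stronger inhibition), compound 3 gives 9140 nM and sits level with compound 1 within the scatter (a 1.3-fold lower number from compound 1 to compound 3 (0.12 log units; within the scatter)). Compound 2 gives > 40000 nM as a limit of the assay and not as a number. The gap to that limit is an at least 4.3-fold lower number from compound 2 to compound 3 (0.64 log units; beyond the scatter) and lies beyond the scatter.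

Within the data shown here, compound 4 `Cc1cccc(NC(=O)Nc2cccc(CNc3nccnc3Cl)c2)c1` has no measurement yet. It carries methyl in place of chloro on an aromatic carbon so that 3-chlorophenyl becomes 3-methylphenyl. Among the measured compounds shown here, no measured step makes this exact swap. The closest one exchanges 4-methoxyphenyl for 3-chlorophenyl on an amide-type nitrogen and gave a 1.3-fold lower number from compound 1 to compound 3 (0.12 log units; within the scatter) within the scatter. For the measured compounds named here, the only steps beyond the scatter are an at least 3.3-fold higher number from compound 1 to compound 2 (0.52 log units; beyond the scatter) and an at least 4.3-fold lower number from compound 2 to compound 3 (0.64 log units; beyond the scatter) and both involve the dimethylamino group and rest on the limit of > 40000 nM in this assay, at which 1 of the 3 values shown sits, while the new change involves no such group. No step beyond the scatter is therefore expected in this assay in either direction. The estimated change is a 1.1-fold higher number from compound 3 to compound 4 (0.04 log units; within the scatter) and it should stay small. The expected value for compound 4 is 10000 nM with an estimated range from 4500 nM to 22000 nM in repeated measurements.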

Compound 4, half-maximal inhibitory concentration: 11200 nM
Compound 4: the middle estimate sits 1.1-fold (0.05 log units) below what was measured; measured number inside the range.
By their numbers in this assay, from the lowest: compounds 3, 4 and 1 (each within the scatter of the next). At a limit, above all of these: compound 2.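

In this assay, among these compounds, the exchange of 3-chlorophenyl for 3-methylphenyl gives the first direct reading of this position, and the step is a 1.2-fold higher number from compound 3 to compound 4 (0.09 log units; within the scatter), so on this read-out the chloro and methyl groups cannot be told apart here. The 3-methylphenyl group also matches the 4-methoxyphenyl group, with a 1.1-fold lower number from compound 1 to compound 4 (0.03 log units; within the scatter), which means that three differently substituted phenyl groups now sit together within the scatter. Among the compounds shown, the 4-(dimethylamino)phenyl group alone stands apart, with an at least 3.5-fold lower number from compound 2 to compound 4 (0.55 log units; beyond the scatter), a step that rests on a limit of the assay and not on a number: the limit of > 40000 nM in this assay, at which 1 of the 4 values shown sits.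

Chloro and methyl both count no hydrogen-bond donors or acceptors, so the compounds shown leave open whether a group of another kind at this position, such as a hydroxyl, a carboxylic acid, an amine or a longer chain, would move the number beyond the scatter. They also leave open whether chloro or methyl would read the same at another place on this ring.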